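The source may hold more compounds than are shown below. What is called first, only, known or untested is meant among the compounds shown, and "the series" means these compounds.

Measured so far:
Compound 1 `COc1cc2c(Oc3ccc(NC(=O)c4nn(-c5ccccc5)c(=O)cc4C)cc3F)ccnc2cc1OCCCN1CCCC1` — in a functional assay on HT-29 cells (Homo sapiens) for inhibition, read by MTT assay, with a stated time of 72 h (a lower number here means a stronger inhibitor, a higher number a weaker inhibitor), compound 1 gives 220 nM.
Compound 2 `COc1cc2c(Oc3ccc(NC(=O)c4nn(-c5ccccc5)c(=O)cc4C)cc3F)ccnc2cc1OCCCN1CCN(C)CC1` — in this assay compound 2 gives 270 nM.

Among these two numbers compound 1 has the lowest, and its nearest neighbour is compound 2; the step of a 1.2-fold higher number from compound 1 to compound 2 (0.09 log units; within the scatter) lies within the scatter, so the two cannot be told apart. Compound 3 `COc1cc2c(Oc3ccc(NC(=O)c4nn(-c5ccccc5C(F)(F)F)c(=O)cc4C)cc3F)ccnc2cc1OCCCN1CCCC1` differs from compound 1 by trifluoromethyl in place of hydrogen on an aromatic carbon. For the measured compounds named here, the only measured step swaps pyrrolidin-1-yl for 4-methylpiperazin-1-yl on the saturated chain, a change far from the phenyl that carries the new trifluoromethyl, so no measured comparison speaks directly to this substitution. With nothing pointing either way, the step of a 1.1-fold higher number from compound 1 to compound 3 (0.06 log units; within the scatter) is expected to stay within the scatter, though the uncertainty is wider than for the measured pair. For compound 3 the estimate in this assay is 250 nM, with a range from 80 nM to 800 nM.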

Compound 3, half-maximal inhibitory concentration: 140 nM
Compound 3: middle estimate off by 1.8-fold (0.25 log units), on the high side, and the stated range covers the measured number.
By their numbers in this assay, from the lowest: compounds 3, 1 and 2 (each within the scatter of the next).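

This is the first change shown on the phenyl ring rather than at the end of the saturated chain. In this assay, placing trifluoromethyl on an aromatic carbon of that ring, ortho to a large group, gives a 1.6-fold lower number from compound 1 to compound 3 (0.20 log units; within the scatter), so the two compounds cannot be told apart and this position accepts the four added heavy atoms without a change that can be read. No evidence is available that would explain this result.

Still open, as far as these compounds go, is whether a different group at this same place, such as a methyl, a chlorine or a nitrile, would also leave the number within the scatter. Also open, from the compounds shown here alone, is whether trifluoromethyl would behave the same way in a compound carrying 4-methylpiperazin-1-yl on the chain.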